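Ester prodrug series: pivaloyloxymethyl to isobutyryloxymethyl

The compounds below may be only part of what the source reports. "The series", "measured", "known", "first", "only" and "open" are said of these compounds alone.

Compound 1 `C[C@@H](O)[C@H]1C(=O)N2C(C(=O)OCOC(=O)C(C)(C)C)=C(S[C@@H]3CN[C@H](C(=O)Nc4cccc(C(=O)O)c4)C3)[C@H](C)[C@H]12` is a double-ester parent of the series, carrying a free carboxylic acid on the anilide side. In an ADME assay on a cell-free system (plasma, Rattus norvegicus) for metabolic stability, read by LC-MS, with a stated time of 60 min, at 37 degrees C, tested at 50 uM (a higher number here means that more of the compound is left, a lower number that less of the compound is left), compound 1 gives 0%. Compound 3 `CCOC(=O)C1=C(S[C@@H]2CN[C@H](C(=O)Nc3cccc(C(=O)OCC)c3)C2)[C@H](C)[C@@H]2[C@@H]([C@@H](C)OC(=O)CC)C(=O)N12` gives 0%, and compound 2 `C[C@@H](O)[C@H]1C(=O)N2C(C(=O)OCOC(=O)C(C)(C)C)=C(S[C@@H]3CN[C@H](C(=O)Nc4cccc(C(=O)OCOC(=O)C(C)(C)C)c4)C3)[C@H](C)[C@H]12`, which carries a second (((tert-butyl)carbonyl)oxy)methyl group in place of hydrogen on an oxygen next to a carbonyl group, gives 2%. Compound 1 therefore sits level with compound 3 at the digits shown, the two together at the bottom of the three numbers, and the step of a number 2 percentage points higher from compound 1 to compound 2 (within the scatter) lies within the scatter. Going by the values given here, every compound measured so far is essentially consumed within the assay period.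

Compound 4 `CC(C)C(=O)OCOC(=O)C1=C(S[C@@H]2CN[C@H](C(=O)Nc3cccc(C(=O)O)c3)C2)[C@H](C)[C@@H]2[C@@H]([C@@H](C)O)C(=O)N12` differs from compound 1 by hydrogen in place of methyl on a saturated chain carbon bound to a carbonyl carbon and two saturated chain carbons; cut one bond further out the change reads tert-butyl to isopropyl. Among the compounds with values here, no measured step bears on this change directly. Within the data shown here, the only step available, a number 2 percentage points higher from compound 1 to compound 2 (within the scatter), is within the scatter, and both esters with a free acid, compound 1 and compound 3, read at the floor. For compound 4 no step beyond the scatter is therefore expected, with a number 1 percentage points higher from compound 1 to compound 4 (within the scatter) estimated. The estimate for compound 4 is 1%, with a range from 0% to 8%.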

Compound 4, percent of the compound remaining: 0%
Compound 4: the middle estimate sits 1 percentage points above what was measured; low and high end bracket the measured number.
By their numbers in this assay, from the lowest: compounds 1, 3, 4 and 2 (each within the scatter of the next).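

In this assay, going by these compounds alone, the change from tert-butyl to isopropyl in the ester side chain gives no change at the digits printed from compound 1 to compound 4 (within the scatter), the first direct reading for hydrogen in place of methyl at this saturated chain carbon. Compound 1 and compound 4 both read at the bottom of the scale, so the change does not lift the compound off that floor, and any difference in how fast the two esters disappear within the assay period cannot be read from these numbers. No available evidence accounts for this result.

Still open, going by these compounds, is whether a larger change at this place, such as a longer chain or an amine in the acyl group, leaves more compound remaining. Also open, on these data alone, is how the isopropylcarbonyl group reads with the second carboxylic acid also esterified.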